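The source may report more compounds than this note shows. Statements on the series, on what has been measured and on what is new or still open speak of the compounds shown alone.

Measured compounds:
Compound 1 `COc1cccc2sc(NC(=O)c3ccc(C(F)(F)F)cc3)nc12` — > 10 ug/mL
Compound 2 `Cc1cc2nc(NC(=O)Nc3ccccc3C)sc2cc1C` — 0.1 ug/mL

In a functional assay on MDA-MB-231 cells (Homo sapiens) for antiproliferative activity, read by sulforhodamine B assay (a lower number here means a stronger inhibitor of growth, a higher number a weaker inhibitor of growth), compound 1 gives only a limit, > 10 ug/mL, that is, (the limit of > 10 ug/mL in this assay, at which 1 of the 2 values shown sits). Compound 2 gives 0.1 ug/mL in this assay. Compound 3 `COc1cccc2sc(NC(=O)c3ccc(C#N)cc3)nc12` differs from compound 1 by cyano in place of trifluoromethyl on an aromatic carbon, para to a large group. Among the compounds with values here, because compound 1 sits at the limit of > 10 ug/mL in this assay, at which 1 of the 2 values shown sits, no measured step fixes the size of this change. The step of a number no higher from compound 1 to compound 3 (the limit leaves the size open) is expected to be small, within the scatter. Compound 3 is estimated at 10 ug/mL, between 3 ug/mL and 30 ug/mL.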

Compound 3, concentration for 50% growth inhibition: > 10 ug/mL
Compound 3: a limit, no number; the forecaster's own chance of this, stated with the estimate: 55%; the middle value sits exactly at the limit.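

In this assay, within the data shown here, compound 1 and compound 3 both stand at a limit, so no step between them can be read: the limit of > 10 ug/mL in this assay, at which 2 of the 3 values shown sit.

The compounds shown leave open whether cyano in place of trifluoromethyl changes growth inhibition at all.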